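Benzylamine for thioether in a diamino fused core series

This account rests on a few compounds, and the source may have more. Where it says the series, first, only, none or still open, it means among the compounds named here.

Two compounds of the series carry numbers in a functional assay on SR cells (Homo sapiens) for inhibition, read by sulforhodamine B assay, with a stated time of 48 h; a lower number here means a stronger inhibitor of growth, a higher number a weaker inhibitor of growth. Compound 1 `CCOC(=O)[C@H](CCC(=O)O)NC(=O)c1ccc(Sc2nc3cc(N)cc(N)c3nc2-c2ccccc2)cc1` gives 81300 nM, a weak inhibitor of growth. Compound 2 `Nc1cc(N)c2nc(-c3ccccc3)c(Sc3ccc(F)cc3)nc2c1`, a smaller analogue with a (4-fluorophenyl)sulfanyl group in place of the larger side chain, returns only a limit in this assay, < 100000 nM, so its position is known only as a bound: the limit of < 100000 nM in this assay, at which 1 of the 2 values shown sits. The two values shown are not distinguishable on these data.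

Compound 3 `Nc1cc(N)c2nc(-c3ccccc3)c(NCc3ccc(F)cc3)nc2c1` follows from compound 2 by one change: (4-fluorobenzyl)amino in place of (4-fluorophenyl)sulfanyl on an aromatic carbon. For the measured compounds named here, no measured pair mirrors this change, so the size of the step is open; given how compound 2 stands, a step of any size within the range of this assay would be consistent. The expected step that the limit leaves unreadable from compound 2 to compound 3 is taken as small. Compound 3 is therefore estimated at 50000 nM in this assay, with a range from 10000 nM to 100000 nM.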

Compound 3, concentration for total growth inhibition: < 100000 nM
Compound 3: only a limit was reported; the forecaster's own chance of this, stated with the estimate: 35%; the middle value does not contradict the limit.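

In this assay compound 3 returns only a limit, < 100000 nM. Compound 2 also stands only as a limit, so no step between compound 2 and compound 3 can be read: the limit of < 100000 nM in this assay, at which 2 of the 3 values shown sit.

The compounds shown leave open whether (4-fluorobenzyl)amino and (4-fluorophenyl)sulfanyl differ at all in growth inhibition.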